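This account rests on a few compounds, and the source may have more. Where it says the series, first, only, none or still open, it means among the compounds named here.

Measured so far in a functional assay on KYSE-450 cells (Homo sapiens) for inhibition, read by MTT assay, with a stated time of 48 h; a lower number here means a stronger inhibitor, a higher number a weaker inhibitor:
compound 1 `C/C=C/C(=O)N(Cc1ccc(OC)c([N+](=O)[O-])c1)c1cc(OC)c(OC)c(OC)c1` gives 510 nM;
compound 2 `COc1ccc(CN(C(C)=O)c2cc(OC)c(OC)c(OC)c2)cc1O` gives 160 nM;
compound 3 `C/C=C/C(=O)N(Cc1ccc(OC)c(Br)c1)c1cc(OC)c(OC)c(OC)c1` gives 10500 nM.

Compound 2 stands lowest of the three numbers; compound 1 sits nearest to it and compound 3 furthest, both with higher values. For the measured compounds named here, the one single-point step measured, a 21-fold higher number from compound 1 to compound 3 (1.31 log units; beyond the scatter), concerns the aromatic ring of the benzyl arm and not the acyl side, so it does not bear directly on the change at hand. Compound 4 `COc1ccc(CN(C(=O)C[Se]C#N)c2cc(OC)c(OC)c(OC)c2)cc1O` differs from compound 2 by a group of 3 heavy atoms (1 carbon, 1 nitrogen, 1 selenium; no ring) in place of a hydrogen atom, on a saturated chain carbon bound to a carbonyl carbon. Going by the values given here, no measured pair probes this position, so the expectation leans on compound 2 alone, with a wide range. Compound 4 is expected to give about 200 nM (range 60 nM to 700 nM), an estimated step of a 1.3-fold higher number from compound 2 to compound 4 (0.10 log units; within the scatter).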

Compound 4, half-maximal inhibitory concentration: 280 nM
The estimate for compound 4 lay 1.4-fold (0.15 log units) below the measured number, within the range that was stated.
By their numbers in this assay, from the lowest: compounds 2, 4 and 1 (each within the scatter of the next, the first and the last beyond it); then compound 3.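

In this assay, the saturated chain carbon bound to a carbonyl carbon accepts the group of 3 heavy atoms (1 carbon, 1 nitrogen, 1 selenium; no ring) in place of a hydrogen atom, with a 1.8-fold higher number from compound 2 to compound 4 (0.24 log units; within the scatter). For the compounds shown here, this is the first pair to probe the position, and it shows no separation beyond the scatter despite the added selenium and nitrile. No available evidence bears on the reason for this result. Going by these compounds, whether a sulfur atom in place of selenium, or a methyl group in place of the nitrile, would hold the number stays open. On these data alone, a longer chain carrying the same group is equally open.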